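Swapping a Basic Side Chain for a Ketone Chain

A few compounds are considered here, and "the series" means these few. Any claim that something is new, unique, unknown or untested is made for them only; others in the source may bear on it.

Measured so far:
compound 1 `CCCn1c(=O)n(CC(=O)O)c(=O)c2[nH]cnc21`: 41000 nM
compound 2 `CCCn1c(=O)n(CCN(C)C)c(=O)c2[nH]cnc21`: 2700 nM

In a functional assay (trachea) with Cavia porcellus as the target (a lower number here means that less compound is needed, a higher number that more compound is needed for the effect), compound 2 gives the lowest of the two numbers; its nearest neighbour is compound 1, and the step of a 15-fold lower number from compound 1 to compound 2 (1.18 log units; beyond the scatter) separates them. Compound 3 `CCCn1c(=O)n(CCCCC(C)=O)c(=O)c2[nH]cnc21` has not yet been measured. Its difference from compound 2 is 2-acetylethyl in place of dimethylamino on a saturated chain carbon, two bonds along the chain from an aromatic nitrogen. Within the data shown here, only one measured step exists, a 15-fold lower number from compound 1 to compound 2 (1.18 log units; beyond the scatter), and it put (dimethylamino)methyl in place of carboxy, while compound 3 keeps neither group, so that step bears on the new change only loosely. Among the measured compounds shown here, it shows that the end of the side chain can move the number strongly; no measured compound carries a ketone chain of this kind. Compound 3 is therefore expected to give a number near that of compound 2 or somewhat higher, with a wide range. The estimate for compound 3 in this assay is 5000 nM (from 1500 nM to 20000 nM), which corresponds to an expected step of a 1.9-fold higher number from compound 2 to compound 3 (0.27 log units; within the scatter).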

Compound 3, half-maximal effective concentration: 60 nM
Compound 3: middle estimate off by 83-fold (1.92 log units), on the high side; measured number outside the range, below it.
By their numbers in this assay, from the lowest: compound 3; then compound 2; then compound 1.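

In this assay, the step of a 45-fold lower number from compound 2 to compound 3 (1.65 log units; beyond the scatter) shows that this position tolerates far more than the first pair suggested, and the change is 2-acetylethyl in place of dimethylamino on a saturated chain carbon, two bonds along the chain from an aromatic nitrogen. The comparison with the acid gives a 680-fold lower number from compound 1 to compound 3 (2.83 log units; beyond the scatter) for 3-acetylpropyl in place of carboxy, the widest gap among these compounds. Among the three, then, the lowest number belongs to a chain ending in a ketone, not to the one ending in an amine, and so an amine at the chain end is not needed for a low number here.

Nothing measured explains why the ketone chain does so much better. Going by these compounds, whether the carbonyl itself matters, or the chain length alone, stays open: a plain pentyl or hexyl chain, an alcohol in place of the ketone, or a shorter or longer ketone chain would separate the two.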